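A few compounds are considered here, and "the series" means these few. Any claim that something is new, unique, unknown or untested is made for them only; others in the source may bear on it.

Three compounds share one amide-linked framework and differ in only two places. Compound 1 `Cc1cc(=O)n(-c2ccc(F)cc2)nc1C(=O)Nc1ccc(Oc2ncnc3ccsc23)c(F)c1` carries a 4-fluorophenyl group at one end and one of two closely related cores at the other. In a functional assay on MCF7 cells (Homo sapiens) for cytotoxicity, read by MTT assay, with a stated time of 72 h (a lower number here means a stronger inhibitor, a higher number a weaker inhibitor), compound 1 gives 740 nM. Compound 2 `Cc1cc(=O)n(-c2ccc(F)c(F)c2)nc1C(=O)Nc1ccc(Oc2ncnc3ccsc23)c(F)c1` differs from compound 1 by fluoro in place of hydrogen on an aromatic carbon, and in this assay compound 2 gives 6900 nM, a step of a 9.3-fold higher number from compound 1 to compound 2 (0.97 log units; beyond the scatter). Compound 3 `Cc1cc(=O)n(-c2ccc(F)cc2)nc1C(=O)Nc1ccc(Oc2ncnc3sccc23)c(F)c1` keeps the 4-fluorophenyl group of compound 1 but has the other core; the two cores differ as a group of 9 heavy atoms (6 carbon, 2 nitrogen, 1 sulfur; one five-membered aromatic ring with 1 hetero atom, one six-membered aromatic ring with 2 hetero atoms) in place of a group of 9 heavy atoms (6 carbon, 2 nitrogen, 1 sulfur; one five-membered aromatic ring with 1 hetero atom, one six-membered aromatic ring with 2 hetero atoms), on an oxygen on an aromatic ring. In this assay compound 3 gives 12300 nM, so the change of core is a 17-fold higher number from compound 1 to compound 3 (1.22 log units; beyond the scatter).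

Compound 4 `Cc1cc(=O)n(-c2ccc(F)c(F)c2)nc1C(=O)Nc1ccc(Oc2ncnc3sccc23)c(F)c1` is not yet measured. It combines the core of compound 3 with the same change seen between compound 1 and compound 2, namely (fluoro in place of hydrogen on an aromatic carbon), at the same place. Compound 4 is expected to give about 60000 nM in this assay, most likely between 18000 nM and 200000 nM. The expected step, a 4.9-fold higher number from compound 3 to compound 4 (0.69 log units; beyond the scatter), rests on the earlier step and is kept a little smaller because compound 3 already starts weak at 12300 nM.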

Compound 4, half-maximal inhibitory concentration: 20600 nM
For compound 4 the middle estimate is 2.9-fold (0.46 log units) above the measured one; measured number inside the range.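

On the core of compound 3, the change from 4-fluorophenyl to 3,4-difluorophenyl in this assay gives a 1.7-fold higher number from compound 3 to compound 4 (0.22 log units; within the scatter), so its size does not carry over from the core of compound 1: the same change on two cores in this assay, a 9.3-fold higher number (0.97 log units; beyond the scatter) from compound 1 to compound 2 and a 1.7-fold higher number (0.22 log units; within the scatter) from compound 3 to compound 4, 5.6-fold (0.75 log units) apart, beyond the scatter of two such steps

Read the other way, the change of core with the 3,4-difluorophenyl group gives a 3.0-fold higher number from compound 2 to compound 4 (0.48 log units; beyond the scatter), and this step is also not the same size as the step with the 4-fluorophenyl group: the same change on two cores in this assay, a 17-fold higher number (1.22 log units; beyond the scatter) from compound 1 to compound 3 and a 3.0-fold higher number (0.48 log units; beyond the scatter) from compound 2 to compound 4, 5.6-fold (0.75 log units) apart, beyond the scatter of two such steps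

This shows that, for these four compounds, the two changes do not simply add up, but it rests on a single pair of cores and a single added fluoro, and it does not show why the steps differ or how any other group would carry across.

On these data alone, it remains open whether a chloro or methoxy group in place of the added fluoro would also behave differently on the two cores. As far as these compounds go, it also remains open whether the same gap between steps would appear outside this assay.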